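Ester to Tertiary Amide on a Lipophilic Dienoate Chain

The source may report more compounds than this note shows. Statements on the series, on what has been measured and on what is new or still open speak of the compounds shown alone.

Of the compounds shown here, three have been measured in a physicochemical assay for lipophilicity; on this read-out lower numbers stand for lower lipophilicity and higher numbers for higher lipophilicity. Compound 1 `CCC(C)OC(=O)/C=C(C)/C=C/CC(C)CCCC(C)C` gives 7.69, compound 2 `CCC(C)OC(=O)/C=C(C)/C=C/CC(C)CCCC(C)(C)OC` gives 6.49, and compound 3 `CC(C)=CCCC(C)C/C=C/C(C)=C/C(=O)OC(C)C` gives 6.6. Among the compounds with values here, compound 2 stands lowest of the three numbers, within the scatter of compound 3 and beyond it only to compound 1, a difference described by a number 1.20 log units lower from compound 1 to compound 2 (beyond the scatter), which is the sole step between two measured compounds that differ in one place.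

Compound 4 `CCN(CC)C(=O)/C=C(C)/C=C/CC(C)CCCC(C)(C)OC` is the next candidate. It differs from compound 2 in one place: diethylamino in place of sec-butoxy on a carbonyl carbon. Within the data shown here, no measured step covers this exchange; the one step that exists concerns the methoxy group and so does not bear on the ester-to-amide change. Without a direct precedent, the account can only estimate. Compound 4 is expected to come out lower than compound 2 in this assay by a step of about a number 0.99 log units lower from compound 2 to compound 4 (beyond the scatter), beyond the scatter. The estimate for compound 4 is therefore 5.5, with a range from 4.9 to 6.1.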

Compound 4, partition coefficient: 4.82
The estimate for compound 4 lay 0.68 log units above the measured number, outside the stated range (below it).
By their numbers in this assay, from the lowest: compound 4; then compounds 2 and 3 (each within the scatter of the next); then compound 1.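

In this assay, within the data shown here, the exchange of sec-butoxy for diethylamino on a carbonyl carbon gives a number 1.67 log units lower from compound 2 to compound 4 (beyond the scatter) and so shows that this position also carries a large step, which the earlier compounds could not show, since their one step, a number 1.20 log units lower from compound 1 to compound 2 (beyond the scatter) for the methoxy change, lay elsewhere on the chain. The change leaves the heavy-atom count of the group at five and replaces its oxygen with nitrogen, so the large step comes with no difference in that count. Nothing available accounts for the size of this step.

Going by these compounds, whether ethylamino, piperidinyl or a carboxylic acid at this carbonyl carbon would give a step of similar size remains open. So does whether diethylamino would give a similar step on the chain of compound 1, which lacks the methoxy group.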